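Methoxy to methylsulfanyl on a shared core

This account rests on a few compounds, and the source may have more. Where it says the series, first, only, none or still open, it means among the compounds named here.

Of the compounds shown here, two have been tested in a functional assay on HTB-54 cells (Homo sapiens) for cytotoxicity, read by MTT assay, with a stated time of 72 h; on this read-out lower numbers stand for stronger inhibition of growth and higher numbers for weaker inhibition of growth. Compound 1 `COc1ccc(CNc2nc([Se]C)nc3ccccc23)cc1` carries a methyl on its selenium. In this assay compound 1 gives only a limit of the assay, > 100000 nM. Compound 2 `COc1ccc(CNc2nc([SeH])nc3ccccc23)cc1` differs by a hydrogen in place of that methyl. In this assay, going by the values given here, compound 2 gives 60900 nM, the only actual number so far. The step of an at least 1.6-fold lower number from compound 1 to compound 2 (0.21 log units; that floor lies within the scatter) is set against (the limit of > 100000 nM in this assay, at which 1 of the 2 values shown sits), so its true size is not known. Compound 3 `CSc1ccc(CNc2nc([SeH])nc3ccccc23)cc1` keeps the selenium-bound hydrogen of compound 2 and changes the ring substituent instead: methylsulfanyl in place of methoxy on an aromatic carbon. Among the compounds with values here, no measured step touches this part of the molecule; the single step known concerns the selenium and rests on a limit. There is therefore no basis for expecting a shift in this assay beyond the scatter in either direction. Compound 3 is accordingly estimated at 60000 nM, with a range from 20000 nM to 150000 nM. The step of a 1.0-fold lower number from compound 2 to compound 3 (0.01 log units; within the scatter) that this estimate implies is expected to stay within the scatter.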

Compound 3, concentration for total growth inhibition: > 100000 nM
Compound 3: no number, only a limit (the forecaster's own chance of this, stated with the estimate: 25%); middle value at least 1.6-fold (0.22 log units) away from the limit.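

Going by these compounds alone, this is the first look at the ring substituent rather than the selenium: in this assay, methylsulfanyl in place of methoxy on an aromatic carbon, para to a large group, gives an at least 1.6-fold higher number from compound 2 to compound 3 (0.21 log units; that floor lies within the scatter). The result for compound 3 is a limit of the assay and not a number, so this swap brought no measurable gain in growth inhibition, though the printed floor of the step lies within the scatter and does not by itself establish a real loss. The true size of the step stays unknown because it ends at the assay's ceiling, where most of this small series now sits: the limit of > 100000 nM in this assay, at which 2 of the 3 values shown sit.

Within the data shown here, compound 2 remains the only compound with an actual number, so it is still unclear how sensitive this ring position is, or whether a small change there can move the value at all. Also open, as far as these compounds go, is what a hydroxyl, an amine or a chlorine at this place would give, and whether any such group could bring the value clearly below that of compound 2.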